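From chloropyridine to chlorophenol on the shared core

The compounds below may be only part of what the source reports. "The series", "measured", "known", "first", "only" and "open" are said of these compounds alone.

Compound 3 `COc1cc(C(=O)N2CCC(O)C(C)C2)cc2nc(NCc3cccc(Cl)n3)oc12` gives 580 nM in an assay on isolated protein for inhibition of thyroid hormone receptor beta (Homo sapiens), read by fluorescence, with a stated time of 30 min (a lower number here means a stronger inhibitor, a higher number a weaker inhibitor), the second highest of the three numbers measured. Compound 1 `COc1cc(C(=O)N2CCC(O)C(C)C2)cc2nc(NCc3cc(Cl)ccn3)oc12` gives 190 nM, and compound 2 `COc1cc(C(=O)N2CCC(O)C(C)C2)cc2nc(NCc3ccnc(Cl)c3)oc12` gives 6900 nM. The steps of a 3.1-fold higher number from compound 1 to compound 3 (0.48 log units; beyond the scatter) and a 12-fold lower number from compound 2 to compound 3 (1.08 log units; beyond the scatter) show that exchanging one chloropyridinyl isomer for another moves the number well beyond the scatter. Compound 4 `COc1cc(C(=O)N2CCC(O)C(C)C2)cc2nc(NCc3cc(Cl)ccc3O)oc12` carries 5-chloro-2-hydroxyphenyl in place of 6-chloropyridin-2-yl on a saturated chain carbon bound to a nitrogen on an aromatic ring. Within the data shown here, none of the measured steps exchanges the pyridine for a carbon-only ring or introduces a hydroxyl, so the direction of this step is not indicated by the data. Because a 3.1-fold higher number from compound 1 to compound 3 (0.48 log units; beyond the scatter) and a 12-fold lower number from compound 2 to compound 3 (1.08 log units; beyond the scatter) both passed the scatter, compound 4 is expected to differ from compound 3, and the step of a 1.2-fold higher number from compound 3 to compound 4 (0.08 log units; within the scatter) is an estimate with a wide range. The estimate for compound 4 is 700 nM, between 150 nM and 3500 nM.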

Compound 4, half-maximal inhibitory concentration: 170 nM
Estimate against measurement, compound 4: 4.1-fold (0.61 log units) above; low and high end bracket the measured number.
By their numbers in this assay, from the lowest: compounds 4 and 1 (each within the scatter of the next); then compound 3; then compound 2.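

A ring of carbon only, carrying a hydroxyl, serves at this place as well as 4-chloropyridin-2-yl does, with a 1.1-fold lower number from compound 1 to compound 4 (0.05 log units; within the scatter), so a ring nitrogen is not needed for a number at this level. The same 5-chloro-2-hydroxyphenyl group gives lower numbers than the other two chloropyridinyl isomers, with a 3.4-fold lower number from compound 3 to compound 4 (0.53 log units; beyond the scatter) and a 41-fold lower number from compound 2 to compound 4 (1.61 log units; beyond the scatter). Nothing available explains these steps. As far as these compounds go, whether the hydroxyl itself accounts for them stays open, as does how a methoxy group or an amine in its place, or a 3-chlorophenyl ring without it, would read.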